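The compounds below may be only part of what the source reports. "The series", "measured", "known", "first", "only" and "open" are said of these compounds alone.

Measured so far:
compound 1 `CCc1cc(C(=O)OCO[P@@]2(=O)OCC(C)(C)[C@H](C(=O)NCCC(=O)OC)O2)n(C)n1` — >= 0.97 h
compound 2 `COC(=O)CCNC(=O)[C@@H]1O[P@](=O)(OCOC(=O)c2cc(C)nn2C)OCC1(C)C` — < 0.16 h
compound 3 `COC(=O)CCNC(=O)[C@@H]1O[P@](=O)(OCOC(=O)c2ccns2)OCC1(C)C` — < 0.16 h

In an ADME assay on blood (Homo sapiens) for pharmacokinetics (a lower number here means that the compound disappears faster, a higher number that the compound lasts longer), compound 3 gives < 0.16 h, which is a limit of the assay and not a number. Compound 2 sits at the same kind of limit with < 0.16 h. Compound 1 stands at the other end of the range, where >= 0.97 h is again a limit and not a number. So the three values shown are all limits: two at the limit of < 0.16 h in this assay, at which 2 of the 3 values shown sit, and one at the limit of >= 0.97 h in this assay, at which 1 of the 3 values shown sits.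

The step from compound 3 to compound 4 `CCc1cc(C(=O)OCO[P@]2(=O)OCC(C)(C)[C@H](C(=O)NCCC(=O)OC)O2)n(C)n1` is 3-ethyl-1-methyl-1H-pyrazol-5-yl in place of 1,2-thiazol-5-yl on a carbonyl carbon. Going by the values given here, the one measured step that touches a change of this kind, a step that the two limits leave unreadable from compound 2 to compound 3, cannot be read in size because both ends are limits. What bears on the direction is that compound 1, which also carries the 3-ethyl-1-methyl-1H-pyrazol-5-yl group, gives >= 0.97 h in this assay. On that ground compound 4 is expected to move upward from compound 3 by an at least 6.2-fold higher number from compound 3 to compound 4 (0.79 log units; beyond the scatter) in this assay. The estimate for compound 4 is 1 h, within a range from 0.25 h to 3 h, with a real chance that only a limit is reported.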

Compound 4, half-life: < 0.16 h
Compound 4 was reported as a limit (the forecaster's own chance of this, stated with the estimate: 50%); at least 6.2-fold (0.79 log units) between middle value and limit.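

Going by these compounds alone, the result shows that the 3-ethyl-1-methyl-1H-pyrazol-5-yl group on a carbonyl carbon does not by itself settle the outcome in this assay: the group is present at both ends of the one readable step, which is an at least 6.0-fold lower number from compound 1 to compound 4 (0.78 log units; beyond the scatter), and both ends of that step are limits of the assay and not numbers. The gap can be put down to the stereocentre at phosphorus, drawn S in compound 1 and R in compound 4, because of this: the fact that compounds 1 and 4 differ only in the configuration as drawn The other two new steps cannot be read, as both ends of each are limits, and compound 2, compound 3 and compound 4 all sit together at the low end of the range: the limit of < 0.16 h in this assay, at which 3 of the 4 values shown sit.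

On these data alone, it remains open whether the configuration at phosphorus matters as much with a 1,2-thiazol-5-yl or a 1,3-dimethyl-1H-pyrazol-5-yl group on the carbonyl carbon, or with a phenyl or a tert-butyl group in that place. As far as these compounds go, how far the true half-lives lie beyond these limits also stays open, so the full size of the gap is unknown.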